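The source may hold more compounds than are shown below. What is called first, only, known or untested is meant among the compounds shown, and "the series" means these compounds.

In a functional assay on CCRF-CEM cells (Homo sapiens) for inhibition, read by MTT assay, with a stated time of 72 h (a lower number here means a stronger inhibitor, a higher number a weaker inhibitor), compound 1 `COc1cccc(/C=C/C(=O)Nc2cc(OC)c(OC)c(OC)c2)c1` gives 23400 nM as the reference point for this step. Compound 3 `C=C(Br)C(=O)Nc1cccc(/C=C/C(=O)Nc2ccc(OC(F)(F)F)cc2)c1` (13000 nM) lies within the scatter of compound 1, while compound 2 `C=C(Br)C(=O)Nc1cccc(/C=C/C(=O)NCc2ccc(C)cc2)c1` (550 nM) lies far lower than both. Compound 4 `C=C(Br)C(=O)Nc1cccc(/C=C/C(=O)Nc2cc(OC)c(OC)c(OC)c2)c1` differs from compound 1 in one place, with ((1-bromoethenyl)carbonyl)amino in place of methoxy on an aromatic carbon. Among the measured compounds shown here, no measured pair isolates this change. Compound 2 (550 nM) and compound 3 (13000 nM) both carry the entering group yet stand far apart, so the group alone does not fix the number. The estimated step of a 9.4-fold lower number from compound 1 to compound 4 (0.97 log units; beyond the scatter) points to a lower number, moderately beyond the scatter. Compound 4 is expected in this assay at an estimated 2500 nM (range 500 nM to 12000 nM).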

Compound 4, half-maximal inhibitory concentration: 59 nM
Compound 4: the middle estimate sits 42-fold (1.63 log units) above what was measured; the measured number lies below the stated range.
By their numbers in this assay, from the lowest: compound 4; then compound 2; then compounds 3 and 1 (each within the scatter of the next).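

In this assay, the step of a 400-fold lower number from compound 1 to compound 4 (2.60 log units; beyond the scatter) comes with ((1-bromoethenyl)carbonyl)amino in place of methoxy on an aromatic carbon, meta to a large group. With the rest of the core of compound 1 unchanged, this single change moves the number far beyond the scatter, so this position is highly sensitive to what it carries. Nothing measured here accounts for the size of this step. From the compounds shown here alone, whether the bromine is required remains open, and a bromine-free acryloylamino group at this position would test that. A simple amine or acetylamino group there would show how much of the step survives without the bromoethenyl part.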